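Methoxycarbonyl for chloro on a quinolone carboxamide core

The source may hold more compounds than are shown below. What is called first, only, known or untested is meant among the compounds shown, and "the series" means these compounds.

Of the compounds shown here, two of one series have been measured in an assay on isolated protein for inhibition of tyrosine-protein kinase receptor UFO (Homo sapiens), read by FRET and Z'-LYTE, with a stated time of 1.5 h; on this read-out higher numbers stand for weaker inhibition and lower numbers for stronger inhibition. Compound 1, `Cc1c(C(=O)Nc2ccc(Oc3ncnc4[nH]cc(-c5ccccc5)c34)c(F)c2)c(=O)c2cc(Cl)ccc2n1C`, gives 1890 nM in this assay. Compound 2, `CCc1ccc2c(c1)c(=O)c(C(=O)Nc1ccc(Oc3ccnc(N)c3Cl)c(F)c1)c(C)n2C`, gives 72 nM in this assay. Of the two numbers, compound 1 stands highest, and the gap to compound 2 lies beyond the usual scatter of repeated measurements; since compound 2 differs from compound 1 at more than one place, the values alone show no single cause.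

Compound 3, `COC(=O)c1ccc2c(c1)c(=O)c(C(=O)Nc1ccc(Oc3ncnc4[nH]cc(-c5ccccc5)c34)c(F)c1)c(C)n2C`, has not yet been measured. It differs from compound 1 in one place: methoxycarbonyl in place of chloro on an aromatic carbon. Among the measured compounds shown here, no pair of measured compounds differs only at this aromatic carbon, so no measured step can guide the expectation, and the change is treated as one of uncertain direction.

The step of a 1.3-fold lower number from compound 1 to compound 3 (0.10 log units; within the scatter) is expected to be small, with no strong reason for a change beyond the scatter in either direction. Compound 3 is estimated to give 1500 nM in this assay, within a range from 450 nM to 5000 nM.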

Compound 3, half-maximal inhibitory concentration: > 10000 nM
Compound 3 gave a limit, no number; the forecaster's own chance of this, stated with the estimate: 5%; at least 6.6-fold (0.82 log units) between middle value and limit.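

Compound 3 carries a limit and not a number in this assay: the limit of > 10000 nM in this assay, at which 1 of the 3 values shown sits.

Even so, the change can be read in one direction: methoxycarbonyl in place of chloro gives an at least 5.2-fold higher number from compound 1 to compound 3 (0.72 log units; beyond the scatter), which means weaker inhibition. The earlier compounds shown here differ at more than one place and could not isolate this aromatic carbon, meta to a fused ring and para to a fused ring, whereas this single change shows that the position does not accept every replacement of chloro without a loss of inhibition. The limit leaves the full size of the step unknown, and the values give no reason for it.

As far as these compounds go, whether a carboxylic acid, a primary amide or a methoxy group on this carbon would keep inhibition close to that of compound 1 remains open. Also open, from the compounds shown here alone, is whether methoxycarbonyl would bring a similar loss on the otherwise different structure of compound 2, which carries ethyl on its core.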